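A few compounds are considered here, and "the series" means these few. Any claim that something is new, unique, unknown or untested is made for them only; others in the source may bear on it.

Working notes on the series. The read-out throughout is a functional assay on MKN-74 cells (Homo sapiens) for antiproliferative activity, with a stated time of 24 h; on this read-out lower numbers stand for stronger inhibition and higher numbers for weaker inhibition. Compound 1 `NC(=O)c1c(NC(=O)c2ccccc2Cl)sc2c1CCN(C(=S)Nc1ccccc1)C2` gives 15600 nM in this assay. Compound 2 `NC(=O)c1c(NC(=O)c2ccccc2Cl)sc2c1CCN(C(=S)Nc1cccc3ccccc13)C2`, with naphthalen-1-yl in place of phenyl on the amide-type nitrogen, gives 20700 nM in this assay; the step of a 1.3-fold higher number from compound 1 to compound 2 (0.12 log units; within the scatter) is within the scatter. Among the measured compounds shown here, of the two numbers in hand, compound 2 carries the higher one, but its only neighbour, compound 1, sits within the scatter of it, so no order between the two is claimed.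

Compound 3 `NC(=O)c1c(NC(=O)c2ccccc2Cl)sc2c1CCN(C(=S)Nc1ccccc1F)C2` is the next member. The change from compound 2 to compound 3 is 2-fluorophenyl in place of naphthalen-1-yl on an amide-type nitrogen. For the measured compounds named here, the one measured step that bears on it is a 1.3-fold higher number from compound 1 to compound 2 (0.12 log units; within the scatter), which exchanged phenyl for naphthalen-1-yl at the same nitrogen without moving the number beyond the scatter; the move to 2-fluorophenyl largely reverses that exchange and adds a fluorine for which no measured step exists. The expected step of a 1.4-fold lower number from compound 2 to compound 3 (0.14 log units; within the scatter) is therefore small, with no direction beyond the scatter. For compound 3 the estimate in this assay is 15000 nM, with a range from 6000 nM to 40000 nM.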

Compound 3, half-maximal inhibitory concentration: 12600 nM
For compound 3 the middle estimate is 1.2-fold (0.08 log units) above the measured one; low and high end bracket the measured number.
By their numbers in this assay, from the lowest: compounds 3, 1 and 2 (each within the scatter of the next).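

Both new steps in this assay stay within the scatter: 2-fluorophenyl in place of naphthalen-1-yl gives a 1.6-fold lower number from compound 2 to compound 3 (0.22 log units; within the scatter), and fluoro in place of hydrogen on an aromatic carbon gives a 1.2-fold lower number from compound 1 to compound 3 (0.09 log units; within the scatter). Among the compounds shown here, the amide-type nitrogen has now carried phenyl, naphthalen-1-yl and 2-fluorophenyl with no step among compounds 1, 2 and 3 beyond the scatter, so neither the fluorine nor the exchange of two aromatic rings for one separates these compounds on this read-out. No supporting data bear on why these three numbers stay so close.

The compounds shown leave open whether any group at this nitrogen can move the number beyond the scatter, for example a butyl chain in place of the aromatic ring, or a carboxylic acid or a dimethylamino group carried on the phenyl ring. They also leave open how the number responds to changes elsewhere, since the rest of the structure is the same in compounds 1, 2 and 3.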